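Sulfonamide swap on the aryl of compound 1

A few compounds are considered here, and "the series" means these few. Any claim that something is new, unique, unknown or untested is made for them only; others in the source may bear on it.

Three compounds of the series have numbers in an in vitro assay on HEK385-7 cells for displacement of a labelled ligand from prostaglandin D2 receptor 2 (Homo sapiens); a higher number here means a weaker inhibitor, a lower number a stronger inhibitor. Compound 1 `NS(=O)(=O)c1ccc(-c2nc(C(c3ccc(F)cc3)c3ccc(F)cc3)sc2CC(=O)O)cc1` gives 1500 nM in this assay, the highest of the three numbers. Compound 2 `O=C(O)Cc1sc(C(c2ccccc2)c2ccccn2)nc1-c1ccc(Cl)cc1` gives 810 nM, which sits within the scatter of compound 1, so the two cannot be ordered. Compound 3 `O=C(O)Cc1sc(C(c2ccccc2)c2ccc(O)cc2)nc1-c1ccc(F)cc1` gives 3.4 nM, far below compound 1 and well beyond the scatter. For the measured compounds named here, no pair among the measured compounds differs in a single place, so no measured step is available to anchor the change that follows.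

Compound 4 `CS(=O)(=O)Nc1cccc(-c2nc(C(c3ccc(F)cc3)c3ccc(F)cc3)sc2CC(=O)O)c1` has not yet been measured in this assay. It keeps the core of compound 1 and the group that bears two 4-fluorophenyl rings, and differs from compound 1 in one place: 3-(methanesulfonamido)phenyl in place of 4-sulfamoylphenyl on an aromatic carbon. Both the group that leaves and the group that enters carry a sulfur-bearing substituent on a six-membered aromatic ring of carbon only.

With no measured step of this kind in the series, the step from compound 1 to compound 4 is expected to be modest, a 2.5-fold lower number from compound 1 to compound 4 (0.40 log units; beyond the scatter), toward a lower number, with real uncertainty on direction. Compound 4 is estimated at 600 nM in this assay, with a range from 150 nM to 3000 nM.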

Compound 4, half-maximal inhibitory concentration: 40 nM
Estimate against measurement, compound 4: 15-fold (1.18 log units) above; measured number outside the range, below it.
By their numbers in this assay, from the lowest: compound 3; then compound 4; then compounds 2 and 1 (each within the scatter of the next).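

The exchange of 4-sulfamoylphenyl for 3-(methanesulfonamido)phenyl, on the aromatic carbon next to the ring nitrogen, gives a 38-fold lower number from compound 1 to compound 4 (1.57 log units; beyond the scatter) in this assay. For the compounds shown here, this is the only single-place step so far, and it shows that the number at this position responds strongly to how the sulfur-bearing substituent is built and placed on the phenyl ring, even with the group that bears two 4-fluorophenyl rings and the rest of the core held constant. Going by these compounds alone, the leaving and entering groups have the same counts of hydrogen-bond donors and acceptors and differ by little in size, so those counts do not track the step, and no measurement on these compounds speaks to its origin.

From the compounds shown here alone, the step combines two changes, the place of the substituent on the phenyl ring and the form of the sulfonamide, so the share of each stays open; 4-(methanesulfonamido)phenyl and 3-sulfamoylphenyl would separate them. Also open, going by these compounds, is whether the sulfonamide is needed at all, which a carboxamide or a plain methoxy group on the same ring carbon would test.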